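Triazole aryl swap on a phenol-bearing ketone core

The source may report more compounds than this note shows. Statements on the series, on what has been measured and on what is new or still open speak of the compounds shown alone.

Measured compounds:
compound 1 `Cc1ccc(S(=O)(=O)Oc2ccc3c(c2C)[C@H](Cn2cc(-c4ccccn4)nn2)[C@@]24CC(=O)[C@@](C)(CC[C@@H]32)C4)cc1` — > 20000 nM
compound 2 `Cc1c(O)ccc2c1[C@H](Cn1cc(-c3ccccn3)nn1)[C@@]13CC(=O)[C@@](C)(CC[C@@H]21)C3` — > 20000 nM
compound 3 `C=C1C[C@]23C[C@@]1(O)CC[C@H]2c1cc(Br)c(O)c(C)c1[C@@H]3Cn1cc(-c2ccc(Cl)cc2)nn1` — 5590 nM

In a functional assay on HL-60 cells (Homo sapiens) for cytotoxicity, read by MTT assay, with a stated time of 4 days (on this read-out higher numbers stand for weaker inhibition and lower numbers for stronger inhibition), compound 2 gives only a limit, > 20000 nM, so its true position is not known beyond that. Compound 1 likewise returns a limit, > 20000 nM. The step that the two limits leave unreadable from compound 1 to compound 2 therefore cannot be read, because the limit of > 20000 nM in this assay, at which 2 of the 3 values shown sit, holds both ends of it. Within the data shown here, compound 3, which carries a 4-chlorophenyl on the triazole and a differently substituted core, gives 5590 nM; no single-point step connects it to compound 2, so its value stands on its own.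

Compound 4 `COc1ccc(-c2cn(C[C@H]3c4c(ccc(O)c4C)[C@@H]4CC[C@@]5(C)C[C@]43CC5=O)nn2)cc1` differs from compound 2 by 4-methoxyphenyl in place of pyridin-2-yl on an aromatic carbon. Among the measured compounds shown here, no measured step addresses this change, and the only value on the same core is a limit. The expectation therefore rests on little more than the two neighbours: compound 2 at its limit and compound 3 with its aryl triazole at a measurable but weak value.

Compound 4 is expected to remain weak, with an estimated 15000 nM and a range from 4000 nM to 50000 nM, which means an expected step of an at least 1.3-fold lower number from compound 2 to compound 4 (0.12 log units; that floor lies within the scatter).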

Compound 4, half-maximal inhibitory concentration: > 20000 nM
Compound 4 gave a limit, no number (the forecaster's own chance of this, stated with the estimate: 55%); at least 1.3-fold (0.12 log units) between middle value and limit.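

In this assay compound 4 gives only a limit, > 20000 nM. The step from compound 2 to compound 4 cannot be read, because both of its ends are limits: the limit of > 20000 nM in this assay, at which 3 of the 4 values shown sit.

From the compounds shown here alone, whether 4-methoxyphenyl in place of pyridin-2-yl alters cytotoxicity on the shared core remains open, as do the true values of compound 2 and compound 4.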